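This account rests on a few compounds, and the source may have more. Where it says the series, first, only, none or still open, it means among the compounds named here.

Measured in a functional assay on PC-3 cells (Homo sapiens) for cytotoxicity; a lower number here means a stronger inhibitor, a higher number a weaker inhibitor:

- compound 1 `COc1ccc2c(c1)c(/C=N\NC(=O)c1c[nH]c3ccc(Br)cc13)cn2Cc1ccc(Cl)cc1`: 15900 nM
- compound 2 `COc1ccc(Cn2cc(/C=N\NC(=O)c3c[nH]c4ccccc34)c3cc(OC)ccc32)cc1`: 13600 nM
- compound 3 `O=C(N/N=C\c1cn(Cc2ccc(Cl)cc2)c2cc(F)ccc12)c1c[nH]c2ccccc12`: 19500 nM

All three numbers sit close together. Of the three, the number of compound 2 is the smallest, yet compound 1 and compound 3 both stand within the usual scatter of it, so no separation among the three compounds can be claimed from these data, and none of them is called the strongest or weakest.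

Compound 4 `COc1ccc(Cn2cc(/C=N\NC(=O)c3c[nH]c4ccccc34)c3ccccc32)cc1` has not yet been measured in this assay. It differs from compound 2 in one place: hydrogen in place of methoxy on an aromatic carbon. For the measured compounds named here, no pair of measured compounds in this set differs in a single place, so no measured step is available to set the size of this change. Given how narrowly the three measured numbers cluster, the step from compound 2 to compound 4 is expected to be small, with no clear direction, and is estimated as a 1.1-fold higher number from compound 2 to compound 4 (0.04 log units; within the scatter), within the scatter. For compound 4 the expected value in this assay is 15000 nM, with a range from 6000 nM to 40000 nM.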

Compound 4, half-maximal inhibitory concentration: 14600 nM
Beside the measured number, compound 4's estimate is 1.0-fold (0.01 log units) above it, and the stated range covers the measured number.
By their numbers in this assay, from the lowest: compounds 2, 4, 1 and 3 (each within the scatter of the next).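

In this assay, for the compounds shown here, hydrogen in place of methoxy on this aromatic carbon gives a 1.1-fold higher number from compound 2 to compound 4 (0.03 log units; within the scatter) and is the only single-place comparison available. At this position, the methoxy, with its 2 heavy atoms and its hydrogen-bond acceptor, can therefore leave without any separation that can be read from this assay. No supporting data bear on the reason for this outcome.

On these data alone, whether an amine, a carboxylic acid or a longer alkoxy chain on this aromatic carbon would separate from compound 2 remains open. Also open, as far as these compounds go, is whether the same exchange of methoxy for hydrogen would read the same way with a different group on the indole-linked benzyl portion of the shared core.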